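The source may report more compounds than this note shows. Statements on the series, on what has been measured and on what is new or still open speak of the compounds shown alone.

Measured compounds:
- Compound 1, `Cn1c(=O)c2nc(-c3ccc(Cl)cc3)[nH]c2n(C)c1=O`, in an assay on membranes from brain for binding affinity to adenosine receptor A1 (Rattus norvegicus), read by radioligand binding (a lower number here means a stronger inhibitor, a higher number a weaker inhibitor), gives 0.8 nM.
- Compound 2, `Cc1nn(C)c2c(O)nc(-c3ccc(Cl)cc3)nc12`, in this assay gives 410 nM.

Compound 2 stands at the higher of the two numbers; its nearest neighbour is compound 1, and the two are far apart, well beyond the scatter of repeated measurements. The two differ in several places at once, so nothing is made of a single change between them.

The step of interest leads from compound 2 to compound 3, `Cc1nn(C)c2c(O)nc(-c3ccc(N)cc3)nc12`. The change is amino in place of chloro on an aromatic carbon. No step of this kind is shown among the measured compounds, so the expectation rests on compound 2 alone. Given that compound 2 already sits at 410 nM, a small to moderate loss is expected in this assay, namely a 2.4-fold higher number from compound 2 to compound 3 (0.39 log units; beyond the scatter), though a step within the scatter cannot be ruled out. Compound 3 is therefore estimated at 1000 nM, within a range from 250 nM to 4000 nM.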

Compound 3, half-maximal inhibitory concentration: 380 nM
Compound 3: the middle estimate sits 2.6-fold (0.42 log units) above what was measured, within the range that was stated.
By their numbers in this assay, from the lowest: compound 1; then compounds 3 and 2 (each within the scatter of the next).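

At this position, on an aromatic carbon para to a large group, amino can stand in place of chloro with no readable change in this assay (a 1.1-fold lower number from compound 2 to compound 3 (0.03 log units; within the scatter)). The step brings in a hydrogen-bond donor and a hydrogen-bond acceptor where chloro counted neither, yet compound 3 and compound 2 stay within the scatter of each other, so this single pair shows no dependence on that difference. Nothing measured here explains why the two compounds read alike.

On these data alone, it remains open whether a carboxylic acid, a methoxy group or a longer chain at this position would also leave the number within the scatter. As far as these compounds go, it is also open whether amino in place of chloro would do the same on the core of compound 1, which gives (0.8 nM).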